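The compounds below may be only part of what the source reports. "The series", "measured", "known", "first", "only" and "open" are said of these compounds alone.

Working notes on the series. Compound 1 `CNc1nc(C)c(C(=O)N/N=C/c2cccc(C(F)(F)F)c2)s1` and compound 2 `CNc1nc(C(F)(F)F)c(C(=O)N/N=C/c2cccc(C(F)(F)F)c2)s1` share the core and differ in a single group. In a functional assay on HeLa cells (Homo sapiens) for inhibition, read by MTT assay, with a stated time of 72 h (a higher number here means a weaker inhibitor, a lower number a stronger inhibitor), compound 1 gives > 100 ug/mL, which is a limit of the assay and not a number. In this assay compound 2 gives > 100 ug/mL, likewise a limit. Going by the values given here, the only recorded step, a step that the two limits leave unreadable from compound 1 to compound 2, is therefore unreadable in size. Compound 2 thus stands at the limit of > 100 ug/mL in this assay, at which 2 of the 3 values shown sit, with no number of its own. Among the compounds with values here, compound 3 `CN(C(=O)NC(=O)c1cccc(C(F)(F)F)c1)c1nc(C(F)(F)F)c(C(=O)N/N=C/c2cc(C(F)(F)F)cc(C(F)(F)F)c2)s1` carries a substituted carbamoyl group on the ring nitrogen and in this assay gives 5.34 ug/mL, the only number among the measured compounds.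

Compound 4 `CN(C(=O)NC(=O)c1ccccc1F)c1nc(C(F)(F)F)c(C(=O)N/N=C/c2cccc(C(F)(F)F)c2)s1` is still to be measured. Relative to compound 2 the change is ((2-fluorophenyl)carbonyl)carbamoyl in place of hydrogen on a nitrogen on an aromatic ring. Within the data shown here, no measured step reports this change; the one step recorded, a step that the two limits leave unreadable from compound 1 to compound 2, concerns another position and its size cannot be read. Compound 3 also bears a substituted carbamoyl group on that nitrogen, but it differs from compound 4 in two places, so only its value and the limit for compound 2 can be set side by side, and they point in the direction of a number appearing for compound 4. Compound 4 is therefore expected to show a step of an at least 10-fold lower number from compound 2 to compound 4 (1.00 log units; beyond the scatter) toward stronger inhibition. The estimate for compound 4 is 10 ug/mL, with a range from 3 ug/mL to 40 ug/mL.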

Compound 4, half-maximal inhibitory concentration: 19.1 ug/mL
Estimate against measurement, compound 4: 1.9-fold (0.28 log units) below, within the range that was stated.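

Substitution on this nitrogen gives the first readable step in the series: in this assay, ((2-fluorophenyl)carbonyl)carbamoyl in place of hydrogen gives an at least 5.2-fold lower number from compound 2 to compound 4 (0.71 log units; beyond the scatter). From the compounds shown here alone, the true size of this step remains unknown, as it starts from a limit of the assay and not a number: the limit of > 100 ug/mL in this assay, at which 2 of the 4 values shown sit. Going by these compounds alone, compound 3 also carries a substituted carbamoyl group on this nitrogen, but it differs from compound 4 in two places, so the pair of compound 2 and compound 4 is the first to isolate this change at this position.

It remains open which part of the entering group accounts for the step: the 2-fluorophenyl ring, the carbonyl joined to it or the carbamoyl. Also open, going by these compounds, is whether a plain acetyl group or an unsubstituted carbamoyl on this nitrogen, or an amine or a carboxylic acid in place of the fluorine on the phenyl ring, would give a number in this assay, and whether the same change would have a similar effect on compound 1.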